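The source may hold more compounds than are shown below. What is called first, only, known or untested is meant among the compounds shown, and "the series" means these compounds.

Compound 1 `CCOC(=O)C1=C(C)NC(c2ccccc2)=CC1c1ccc(OC)cc1` belongs to a small set of three compounds tested in an assay on SH-SY5Y cells for inhibition of Voltage-dependent L-type calcium channel subunit alpha-1D (Homo sapiens), read by calcium flux, with a stated time of 15 min; a higher number here means a weaker inhibitor, a lower number a stronger inhibitor. Compound 1 gives 29800 nM, the highest of the three numbers, though within the scatter of both others. Compound 2 `COc1ccc(C2C=C(c3ccccc3)NC(C)=C2C(=O)SC(C)(C)C)cc1` gives 26800 nM, and compound 3 `CCOC(=O)C1=C(C)NC(c2ccc(Cl)cc2)=CC1c1cccc(OC)c1` gives 15100 nM; compound 3 differs from compound 1 in two places, and its value and that of compound 1 simply lie within the scatter of each other. For the measured compounds named here, the only single-place step measured is a 1.1-fold lower number from compound 1 to compound 2 (0.05 log units; within the scatter), a change at the carbonyl carbon that leaves the aromatic rings untouched.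

Compound 4 `CCOC(=O)C1=C(C)NC(c2ccccc2)=CC1c1ccc([N+](=O)[O-])cc1` has not yet been measured. It differs from compound 1 by nitro in place of methoxy on an aromatic carbon. Going by the values given here, no measured step touches this part of the molecule, so the step from compound 1 to compound 2 gives no guide to the direction here. The expected step is therefore one no larger than the scatter, with a 1.7-fold lower number from compound 1 to compound 4 (0.22 log units; within the scatter) as the estimated outcome. Compound 4 is expected to give 18000 nM, with a range from 6000 nM to 50000 nM.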

Compound 4, half-maximal inhibitory concentration: 12200 nM
Beside the measured number, compound 4's estimate is 1.5-fold (0.17 log units) above it; measured number inside the range.
By their numbers in this assay, from the lowest: compounds 4, 3, 2 and 1 (each within the scatter of the next, the first and the last beyond it).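

In this assay, for the compounds shown here, changing 4-methoxyphenyl to 4-nitrophenyl gives a 2.4-fold lower number from compound 1 to compound 4 (0.39 log units; beyond the scatter) and is the first single-place step in this set to clear the scatter. This shows that the number can respond to a change on this aromatic carbon, whereas the step at the carbonyl carbon, a 1.1-fold lower number from compound 1 to compound 2 (0.05 log units; within the scatter), does not separate those two compounds. No measurement here bears on what lies behind the new step.

A single swap also cannot show whether the number follows any trend across groups at this place, so an amine, a carboxylic acid or a nitrile there remains an open case. Going by these compounds, it is also open whether nitro would bring a similar step on the core of compound 2, which carries tert-butylsulfanyl on the carbonyl carbon.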